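This account rests on a few compounds, and the source may have more. Where it says the series, first, only, none or still open, it means among the compounds named here.

Three compounds with a shared core have been examined in an ADME assay on the whole organism (plasma, Macaca fascicularis) for protein binding, read by LC-MS, using equilibrium dialysis and cassette dosing, with a stated time of 24 h, at a dose of 1 mg/kg by the oral route; on this read-out higher numbers stand for a larger free fraction and lower numbers for a smaller free fraction. Compound 1 `C[C@H](c1ccc(-c2cc(F)ccc2-c2nc(=O)o[nH]2)cc1)N(CC1CC1)c1nc2c(C(=O)O)cccc2o1` gives 0.0000977. Compound 2 `CCCCN(c1nc2c(C(=O)O)cccc2o1)[C@H](C)c1ccc(-c2cc(Cl)ccc2-c2nc(=O)o[nH]2)cc1` gives 0.000135, which is the second highest of the three numbers; its nearest neighbour is compound 1, whose number lies within the usual scatter of compound 2, while compound 3 `CCCCN(c1nc2c(C(=O)O)cccc2o1)[C@H](C)c1ccc(-c2ccccc2-c2nnn[nH]2)cc1` gives 0.000285, a number that stands beyond the scatter above compound 2. No two of these measured compounds differ in only one place, so no single-change step can be read from them.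

Compound 4 `CCCCN(c1nc2c(C(=O)O)cccc2o1)[C@H](C)c1ccc(-c2cc(F)ccc2-c2nc(=O)o[nH]2)cc1` has not yet been measured in this assay. Its difference from compound 2 is a single one: fluoro in place of chloro on an aromatic carbon. Among the measured compounds shown here, since no measured pair shows what this exchange does on its own, the expectation rests on the closeness of the measured numbers. The step of a 1.1-fold higher number from compound 2 to compound 4 (0.05 log units; within the scatter) is expected to be small, in neither direction beyond the scatter. Compound 4 is therefore estimated at 0.00015, with a range from 0.00008 to 0.0003.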

Compound 4, unbound fraction: 0.0000736
The estimate for compound 4 lay 2.0-fold (0.31 log units) above the measured number; the whole stated range lies above it.
By their numbers in this assay, from the lowest: compounds 4, 1 and 2 (each within the scatter of the next); then compound 3.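

In this assay, among the compounds shown here, the exchange of chloro for fluoro gives the first direct reading at this aromatic carbon, meta to a large group and para to a group of 6 heavy atoms: a 1.8-fold lower number from compound 2 to compound 4 (0.26 log units; within the scatter), so at this position the exchange does not move the unbound fraction beyond the scatter. The same holds for propyl in place of cyclopropyl on the saturated chain carbon, with a 1.3-fold lower number from compound 1 to compound 4 (0.12 log units; within the scatter), so neither single change separates its pair in this read-out. Nothing measured here offers an explanation for either step.

From the compounds shown here alone, whether a bromo or methyl group on this aromatic carbon, or a longer chain on the saturated chain carbon, would also stay within the scatter remains open. Compound 3 differs from the others in more than one place, so which of its differences bears on its number cannot be read.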